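The source may hold more compounds than are shown below. What is called first, only, known or untested is meant among the compounds shown, and "the series" means these compounds.

In a functional assay on KB cells (Homo sapiens) for antiproliferative activity, read by MTT assay, with a stated time of 72 h (a higher number here means a weaker inhibitor, a lower number a stronger inhibitor), the three measured compounds stand as follows:

compound 1, `CN(C(=O)C(C)(C)C)c1ccc2[nH]c(-c3n[nH]c4ccccc34)cc2n1`: 8390 nM
compound 2, `CN(C(=O)CCc1ccccc1)c1ccc2[nH]c(-c3n[nH]c4ccccc34)cc2n1`: 7380 nM
compound 3, `CN(C(=O)c1ccc(Cl)cc1)c1ccc2[nH]c(-c3n[nH]c4ccccc34)cc2n1`: 630 nM

Compound 3 gives the lowest number of the three in this assay. The step of a 13-fold lower number from compound 1 to compound 3 (1.12 log units; beyond the scatter) and the step of a 12-fold lower number from compound 2 to compound 3 (1.07 log units; beyond the scatter) are both large, whereas the step of a 1.1-fold lower number from compound 1 to compound 2 (0.06 log units; within the scatter) is within the scatter; the shared core is kept throughout and only the group on the carbonyl carbon differs.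

Compound 4, `CN(C(=O)c1ccc(Br)cc1)c1ccc2[nH]c(-c3n[nH]c4ccccc34)cc2n1`, is not yet measured. It differs from compound 3 in one place: bromo in place of chloro on an aromatic carbon, on an aromatic carbon of a six-membered aromatic ring of carbon only, para to a large group. Within the data shown here, none of the measured steps exchanges one halogen for another on that ring; they only show that replacing tert-butyl or phenethyl by 4-chlorophenyl lowers the number greatly. Among the measured compounds shown here, for the swap from chloro to bromo no step of that kind exists among the compounds measured, so no shift beyond the scatter is expected. Compound 4 is therefore estimated at 600 nM, with a range from 250 nM to 1500 nM. The expected step is a 1.1-fold lower number from compound 3 to compound 4 (0.02 log units; within the scatter).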

Compound 4, half-maximal inhibitory concentration: 1780 nM
The estimate for compound 4 lay 3.0-fold (0.47 log units) below the measured number; measured number above the stated range.
By their numbers in this assay, from the lowest: compound 3; then compound 4; then compounds 2 and 1 (each within the scatter of the next).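

In this assay, among these compounds, this position proves sensitive to the identity of the halogen: bromo in place of chloro on an aromatic carbon, para to a large group, gives a 2.8-fold higher number from compound 3 to compound 4 (0.45 log units; beyond the scatter) and thus a difference that the earlier steps, none of which exchanged one halogen for another, could not reveal. The 4-bromophenyl group still retains part of the gain seen with 4-chlorophenyl, with a 4.1-fold lower number from compound 2 to compound 4 (0.62 log units; beyond the scatter) and a 4.7-fold lower number from compound 1 to compound 4 (0.67 log units; beyond the scatter), although these steps are modest whereas those to compound 3 are large. No measured evidence accounts for the difference between chloro and bromo at this position.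

From the compounds shown here alone, how fluoro, iodo, methoxy or an amine would compare at this position remains open. So does how a plain phenyl on the carbonyl carbon would stand against both halogenated groups.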